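Ester variation on the shared core: hydroxyethyl to acetoxyhexyl

The source may hold more compounds than are shown below. What is called first, only, known or untested is meant among the compounds shown, and "the series" means these compounds.

The series keeps one core and varies the ester. Compound 1 `CC(C)=CC[C@@H](OC(=O)c1ccoc1)C1=CC(=O)c2c(O)ccc(O)c2C1=O` carries a furan-3-yl ester; in a functional assay on DU-145 cells (Homo sapiens) for cytotoxicity, read by MTT assay (on this read-out higher numbers stand for weaker inhibition and lower numbers for stronger inhibition), compound 1 gives only a limit, > 100000 nM, which is the limit of > 100000 nM in this assay, at which 1 of the 3 values shown sits. Compound 2 `CC(C)=CC[C@@H](OC(=O)C1CCCCO1)C1=CC(=O)c2c(O)ccc(O)c2C1=O` gives 24700 nM in this assay. Compound 3 `CC(C)=CC[C@@H](OC(=O)CCO)C1=CC(=O)c2c(O)ccc(O)c2C1=O` gives 55300 nM in this assay, the highest of the two numbers; a 2.2-fold higher number from compound 2 to compound 3 (0.35 log units; beyond the scatter), and an at least 1.8-fold lower number from compound 1 to compound 3 (0.25 log units; that floor lies within the scatter).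

Compound 4 `CCCCC(CC(=O)O[C@H](CC=C(C)C)C1=CC(=O)c2c(O)ccc(O)c2C1=O)OC(C)=O` differs from compound 3 by 1-acetoxypentyl in place of hydroxymethyl on a saturated chain carbon bound to a carbonyl carbon. For the measured compounds named here, no measured step swaps a hydroxymethyl for a 1-acetoxypentyl; the nearest step, a 2.2-fold higher number from compound 2 to compound 3 (0.35 log units; beyond the scatter), shows that the 2-hydroxyethyl ester sits higher than the oxan-2-yl ester. A modest move toward lower numbers is therefore expected for compound 4, a 1.8-fold lower number from compound 3 to compound 4 (0.27 log units; within the scatter). Compound 4 is estimated at 30000 nM in this assay, within 10000 nM to 90000 nM.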

Compound 4, half-maximal inhibitory concentration: 67700 nM
Compound 4: middle estimate off by 2.3-fold (0.35 log units), on the low side; low and high end bracket the measured number.
By their numbers in this assay, from the lowest: compound 2; then compounds 3 and 4 (each within the scatter of the next). At a limit, above all of these: compound 1.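

Setting 1-acetoxypentyl in place of hydroxymethyl on a saturated chain carbon bound to a carbonyl carbon gives a step that cannot be read in this assay: a 1.2-fold higher number from compound 3 to compound 4 (0.09 log units; within the scatter). The oxan-2-yl ester stays apart from this acetoxy-bearing chain, with a 2.7-fold higher number from compound 2 to compound 4 (0.44 log units; beyond the scatter), as it does from the 2-hydroxyethyl ester. The step that starts at a limit cannot be read: an at least 1.4-fold lower number from compound 1 to compound 4 (0.16 log units; that floor lies within the scatter). Compound 1 remains a limit: the limit of > 100000 nM in this assay, at which 1 of the 4 values shown sits.

As far as these compounds go, whether an amine or a carboxylic acid at the end of this chain would fall below compound 2 stays open. A plain hexyl chain would be needed to separate the chain from its acetoxy group.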